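The compounds below may be only part of what the source reports. "The series", "measured", "known", "first", "only" and "open" are said of these compounds alone.

Compound 1 `Clc1ccc(-c2cc(-c3cccnc3)nc(-c3ccsc3)c2)o1` has been tested in a functional assay on K562 cells (Homo sapiens) for cytotoxicity, in the presence of a further agent that is not named here (a lower number here means a stronger inhibitor, a higher number a weaker inhibitor), where compound 1 gives 21700 nM. Among the compounds with values here, the only other measured compound, compound 2 `Clc1ccc(-c2cc(-c3ccc(Cl)o3)cc(-c3cccs3)n2)cc1`, gives 20900 nM in this assay. Compound 1 thus holds the higher of the two numbers, but the gap to compound 2 falls within the scatter of repeated measurements, so the two compounds cannot be told apart on these data. Both belong to the same weakly active region of the assay.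

Compound 3 `Cc1ccccc1-c1cc(-c2ccc(Cl)o2)cc(-c2ccsc2)n1` has not yet been measured in this assay. It differs from compound 1 in one place: 2-methylphenyl in place of pyridin-3-yl on an aromatic carbon. Within the data shown here, no pair of measured compounds shows a step of this kind, so there is nothing here from which the direction or size of its effect can be read directly. What the two measured values show is that two different arrangements of the same three kinds of aromatic groups on the shared core land at nearly the same number.

On that basis a modest change at most is expected, with a 1.4-fold lower number from compound 1 to compound 3 (0.16 log units; within the scatter) as the estimated step. For compound 3 the expected value is 15000 nM, with a range from 5000 nM to 45000 nM.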

Compound 3, half-maximal inhibitory concentration: 18400 nM
The estimate for compound 3 lay 1.2-fold (0.09 log units) below the measured number; the measured number falls inside the stated range.
By their numbers in this assay, from the lowest: compounds 3, 2 and 1 (each within the scatter of the next).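

In this assay, 2-methylphenyl in place of pyridin-3-yl on the aromatic carbon next to the ring nitrogen gives a 1.2-fold lower number from compound 1 to compound 3 (0.07 log units; within the scatter), the first step read at this position, and it does not separate the two compounds. The exchange removes the ring nitrogen and the hydrogen-bond acceptor of pyridin-3-yl and brings in a six-membered aromatic ring of carbon only, yet in this assay this one pair shows no change that can be told from the scatter. No measured information is available to explain this result.

Within the data shown here, whether anything placed on this carbon can move the number beyond the scatter remains open, since both groups compared here are six-membered aromatic rings and the single step cannot show how far this holds for other groups. An amine or a carboxylic acid on the same carbon, in place of the aromatic ring, would show whether the number in this assay responds to a change at this position at all.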